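The source may hold more compounds than are shown below. What is called first, only, known or untested is meant among the compounds shown, and "the series" means these compounds.

Compound 1 `O=C1CCCC2=C1C(c1ccc(F)cc1)C=C(c1ccccc1)N2`: 21.9%
Compound 2 `CCOC(=O)C1(O)CC(c2ccc(Cl)cc2)C2=C(CC(C)(C)CC2=O)O1`: "not active" (no number reported)
Compound 3 `CCOC(=O)C1=CC(c2ccccc2)C2=C(CC(C)(C)CC2=O)N1`: "not active" (no number reported)

Three compounds were tested in an assay on isolated protein for inhibition of glucose-6-phosphatase catalytic subunit 1 (Homo sapiens), read by inositol phosphate accumulation, with a stated time of 30 min, tested at 100 uM; on this read-out lower numbers stand for less inhibition and higher numbers for more inhibition at the one concentration tested (going by the name of the read-out). Compound 1 gives 21.9%. Compound 2 is reported as "not active" (no number reported), with no single number behind it, and compound 3 is likewise reported as "not active" (no number reported). So compound 2 stands among the two entries without a figure, while compound 1 alone carries one. Compound 4 `CCOC(=O)C1(O)CC(c2ccc(F)cc2)C2=C(CC(C)(C)CC2=O)O1` has not yet been measured. It differs from compound 2 in one place: fluoro in place of chloro on an aromatic carbon. For the measured compounds named here, no step between measured compounds is known, so the size of this change cannot be read from the data; it is expected to move inhibition in this assay little, if at all, beyond the scatter, most likely again yielding no number. Compound 4 is expected to give about 5%, within a range from -10% to 25%.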

Compound 4, a percentage reported as inhibition, at one concentration (the size of the read-out at that concentration, not a potency): "not active" (no number reported)
Compound 4: no number reported; there is nothing to compare the estimate with.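

For the compounds shown here, compound 2 and compound 4 both come without a number, so no step from 4-chlorophenyl to 4-fluorophenyl can be read, and no other measurement bears on this result. The compounds shown leave open whether this swap changes inhibition at all.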